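Swapping the Aromatic Group on a Shared Core

This account rests on a few compounds, and the source may have more. Where it says the series, first, only, none or still open, it means among the compounds named here.

Among the measured compounds shown here, compound 2 `CCCCCCCCc1ccc(OCC(=O)Cn2nnc(-c3cccnc3)n2)cc1` gives 23 nM in an assay on microsomes from brain for inhibition of Fatty-acid amide hydrolase 1 (Rattus norvegicus), read by fluorescence and HPLC, with a stated time of 60 min (on this read-out lower numbers stand for stronger inhibition and higher numbers for weaker inhibition), the lowest of the two numbers measured so far, although it sits within the scatter of compound 1 `CCCCCCCCc1ccc(OCC(=O)Cn2nnc(-c3cccc(C(=O)OC)c3)n2)cc1`, which gives 34 nM in this assay. For the measured compounds named here, the single measured step, a 1.5-fold lower number from compound 1 to compound 2 (0.17 log units; within the scatter), bears directly on the question at hand, as it too exchanged the aromatic group carried on the same aromatic carbon of the shared core. Compound 3 `CCCCCCCCc1ccc(OCC(=O)Cn2nnc(-c3cccs3)n2)cc1` differs from compound 2 by thiophen-2-yl in place of pyridin-3-yl on an aromatic carbon. Because the step of a 1.5-fold lower number from compound 1 to compound 2 (0.17 log units; within the scatter) remained within the scatter, the expectation is that this further exchange of one aromatic group for another will again change little. The step of a 1.1-fold higher number from compound 2 to compound 3 (0.04 log units; within the scatter) is thus expected to stay within the scatter. Compound 3 is therefore estimated at 25 nM in this assay, with a range from 10 nM to 60 nM.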

Compound 3, half-maximal inhibitory concentration: 32 nM
The estimate for compound 3 lay 1.3-fold (0.11 log units) below the measured number, within the range that was stated.
By their numbers in this assay, from the lowest: compounds 2, 3 and 1 (each within the scatter of the next).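

In this assay, the place on an aromatic carbon of a five-membered aromatic ring with 4 nitrogen now also carries a five-membered aromatic ring: thiophen-2-yl replaces the six-membered pyridin-3-yl, and this exchange gives a step within the scatter (a 1.4-fold higher number from compound 2 to compound 3 (0.14 log units; within the scatter)). Exchanging 3-(methoxycarbonyl)phenyl for thiophen-2-yl also stays within the scatter (a 1.1-fold lower number from compound 1 to compound 3 (0.03 log units; within the scatter)), so the three aromatic groups shown here cannot be told apart on this read-out. Nothing available here accounts for this result.

From the compounds shown here alone, it remains open whether a group without an aromatic ring, such as cyclohexyl or a short alkyl chain, would give a number in this same range at this place. Also open, going by these compounds, is whether a carboxylic acid or an amine on the aromatic ring would do so.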